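The source may hold more compounds than are shown below. What is called first, only, known or untested is meant among the compounds shown, and "the series" means these compounds.

Four compounds built on one shared core are compared here. Compound 1 `CC1=C(C(=O)Nc2ccc([N+](=O)[O-])cc2)C(c2ccc(Br)cc2)N=C(SCc2cccc(Cl)c2)N1` gives 6.7% in a functional assay on the whole organism (artery, strain albino) with Rattus norvegicus as the target, with a stated time of 120 min, at a dose of 10 mg/kg by the oral route; on this read-out higher numbers stand for more inhibition at the one dose given (going by the name of the read-out) and lower numbers for less inhibition. Compound 2 `CC1=C(C(=O)Nc2ccc([N+](=O)[O-])cc2)C(c2ccc(Br)cc2)N=C(SCc2ccc(Cl)cc2)N1` carries 4-chlorophenyl in place of 3-chlorophenyl on a saturated chain carbon bound to a sulfur relative to compound 1; in this assay compound 2 gives 13.9%, so that this change produced a number 7.2 percentage points higher from compound 1 to compound 2 (within the scatter). Compound 3 `CC1=C(C(=O)Nc2ccc([N+](=O)[O-])cc2)C(c2cccc([N+](=O)[O-])c2)N=C(SCc2cccc(Cl)c2)N1` differs from compound 1 in its core by 3-nitrophenyl in place of 4-bromophenyl on a saturated ring carbon, and compound 3 gives 12.4% in this assay; measured against compound 2 the two numbers lie close together.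

Compound 4 `CC1=C(C(=O)Nc2ccc([N+](=O)[O-])cc2)C(c2cccc([N+](=O)[O-])c2)N=C(SCc2ccc(Cl)cc2)N1` has not yet been measured. It differs from compound 3 by 4-chlorophenyl in place of 3-chlorophenyl on a saturated chain carbon bound to a sulfur, which is the same change already seen between compound 1 and compound 2, now made on the core of compound 3. Since the earlier move gave a number 7.2 percentage points higher from compound 1 to compound 2 (within the scatter), the step from compound 3 to compound 4 in this assay is expected to be of similar size, a number 5.6 percentage points higher from compound 3 to compound 4 (within the scatter), though one prior example is a thin basis. On that basis compound 4 is estimated to give 18% in this assay, with a range expected from 5% to 32%.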

Compound 4, a percentage reported as inhibition, in the whole organism at one dose (the size of the read-out at that dose, not a potency): 12.4%
The estimate for compound 4 lay 5.6 percentage points above the measured number; measured number inside the range.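

In this assay, 4-chlorophenyl in place of 3-chlorophenyl gives no change at the digits printed from compound 3 to compound 4 (within the scatter), and 3-nitrophenyl in place of 4-bromophenyl gives a number 1.5 percentage points lower from compound 2 to compound 4 (within the scatter). For the chlorophenyl change, the two cores show no difference that rises above the noise of the measurement: the same change on two cores in this assay, a number 7.2 percentage points higher (within the scatter) from compound 1 to compound 2 and no change at the digits printed (within the scatter) from compound 3 to compound 4, 7.2 percentage points apart, within the scatter of two such steps The same holds for the nitrophenyl change, so nothing here suggests that the core alters either change, yet nothing shows that either change has a real effect that carries from one core to another: the same change on two cores in this assay, a number 5.7 percentage points higher (within the scatter) from compound 1 to compound 3 and a number 1.5 percentage points lower (within the scatter) from compound 2 to compound 4, 7.2 percentage points apart, within the scatter of two such steps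

Still open, from the compounds shown here alone, is whether a quite different group on the saturated ring carbon, such as an amine or a carboxylic acid on the phenyl ring, would give a step large enough to stand clear of the scatter. The same question stands for a longer chain in place of the chlorobenzyl group on the sulfur, and for whether such a step would then hold on both cores.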